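The compounds below may be only part of what the source reports. "The series", "measured", "known", "first", "only" and "open" are said of these compounds alone.

Measured in an ADME assay on HepG2 cells (Homo sapiens) for cytotoxicity, read by MTT assay, with a stated time of 72 h; on this read-out lower numbers stand for higher toxicity in this test and higher numbers for lower toxicity in this test:
Compound 1 `Nc1sc2c(c1-c1nc3ccccc3s1)CCCC2`: 163 ug/mL
Compound 2 `Nc1sc2c(c1-c1nc3cc(Cl)ccc3s1)CCCC2`: 93.7 ug/mL
Compound 3 `C(=C/c1ccccc1)\C=N\c1sc2c(c1-c1nc3ccccc3s1)CCC2`: 215 ug/mL

Compound 1 lies within the usual scatter of both other compounds. Compound 4 `C(=N/c1sc2c(c1-c1nc3ccccc3s1)CCCC2)\c1ccccc1` has not yet been measured. It differs from compound 1 in one place: a group of 8 heavy atoms (7 carbon, 1 nitrogen; one six-membered aromatic ring of carbon only) in place of one nitrogen atom, on an aromatic carbon. The amino group gives way to a group with a six-membered aromatic ring of carbon only. Going by the values given here, the single measured step, a 1.7-fold lower number from compound 1 to compound 2 (0.24 log units; within the scatter), is a different kind of change and offers little guidance. Compound 3, at 215 ug/mL, also lacks the amino group, though its core differs too, so no step beyond the scatter is expected. The expected step is a 1.1-fold higher number from compound 1 to compound 4 (0.04 log units; within the scatter). For compound 4 the estimated value is 180 ug/mL. The expected range for compound 4 runs from 90 ug/mL to 350 ug/mL.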

Compound 4, half-maximal cytotoxic concentration: 308 ug/mL
Compound 4: the middle estimate sits 1.7-fold (0.23 log units) below what was measured; measured number inside the range.
By their numbers in this assay, from the lowest: compounds 2, 1, 3 and 4 (each within the scatter of the next, the first and the last beyond it).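

Swapping the amino group, on the aromatic carbon next to the ring sulfur, for the group carrying a six-membered aromatic ring gives a 1.9-fold higher number from compound 1 to compound 4 (0.28 log units; within the scatter) in this assay. This position therefore takes a much larger group with no hydrogen-bond donor, and the number does not move beyond the usual scatter. No measurement here offers an explanation for this result. Still open, as far as these compounds go, is how a small group at this position, such as an acetyl amide or a methylamine, would read, and what a methoxy group on the new ring would do.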